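The compounds below may be only part of what the source reports. "The series", "measured", "known", "first", "only" and "open" are said of these compounds alone.

Measured so far:
Compound 1, `Nc1ccc2cccc(OC3CCCCC3)c2n1`: 361 nM
Compound 2, `Nc1ccc2cccc(OCCC3CC3)c2n1`: 492 nM

Both were tested in an assay on cells with melanin-concentrating hormone receptor 1 (Homo sapiens) as the target, read by radioligand binding; a higher number here means a weaker inhibitor, a lower number a stronger inhibitor. For the measured compounds named here, compound 2 holds the higher of these two numbers, but its only neighbour is compound 1, and the step of a 1.4-fold higher number from compound 1 to compound 2 (0.13 log units; within the scatter) stays within the scatter, so the two cannot be ranked. Compound 3, `CC(C)C(C)Oc1cccc2ccc(N)nc12`, has not yet been measured. Its change from compound 2 is 1,2-dimethylpropyl in place of 2-cyclopropylethyl on an oxygen on an aromatic ring. Going by the values given here, the one measured step that bears on this, a 1.4-fold higher number from compound 1 to compound 2 (0.13 log units; within the scatter), also exchanged the group on that same oxygen and did not move the number beyond the scatter. Nothing in hand suggests that a branched chain without a ring would behave differently. For compound 3 the expected step is therefore a 1.0-fold higher number from compound 2 to compound 3 (0.01 log units; within the scatter), nothing beyond the scatter. Compound 3 is estimated at 500 nM, with a range from 200 nM to 1300 nM.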

Compound 3, half-maximal inhibitory concentration: 199 nM
For compound 3 the middle estimate is 2.5-fold (0.40 log units) above the measured one; the measured number lies below the stated range.
By their numbers in this assay, from the lowest: compounds 3, 1 and 2 (each within the scatter of the next, the first and the last beyond it).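

In this assay, for the compounds shown here, swapping 2-cyclopropylethyl for 1,2-dimethylpropyl gives a 2.5-fold lower number from compound 2 to compound 3 (0.39 log units; beyond the scatter) and is the first change on this oxygen to pass beyond the scatter, although only modestly, so the number does respond to the group placed here. Both groups have 5 heavy atoms, all carbon, and they differ in that one carries a three-membered ring and the other has no ring, so the step arises without any change in that count. Against cyclohexyl, the same chain gives a 1.8-fold lower number from compound 1 to compound 3 (0.26 log units; within the scatter) and stays within the scatter, so compound 1 and compound 3 cannot be ranked, and no data here explain the shift seen from compound 2. With a single pair, ring and branching cannot be separated as the source of the step. Also open, from the compounds shown here alone, is how this oxygen would tolerate a phenyl ring, an amine or a longer chain.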